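A few compounds are considered here, and "the series" means these few. Any claim that something is new, unique, unknown or untested is made for them only; others in the source may bear on it.

Compound 1: `O=c1nc(NO)c(F)cn1[C@@H]1C[C@@H](O)[C@H](CO)O1` — 920000 nM
Compound 2: `[N-]=[N+]=N[C@@H]1C[C@@H](n2ccc(NO)nc2=O)O[C@H]1CO` — 1160000 nM

Both compounds share the same core and were tested in an ADME assay on HepG2 cells (Homo sapiens) for cytotoxicity, read by MTT assay, with a stated time of 3 days; on this read-out lower numbers stand for higher toxicity in this test and higher numbers for lower toxicity in this test. Compound 2 gives 1160000 nM, the larger of the two numbers shown, but its distance from compound 1, which gives 920000 nM, lies within the scatter of repeated measurements, so the two compounds cannot be told apart on this read-out.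

Compound 3 `O=c1nc(NO)ccn1[C@@H]1C[C@@H](O)[C@H](CO)O1` has not yet been measured. It differs from compound 2 in one place: hydroxy in place of azido on a saturated ring carbon. Within the data shown here, no step between measured compounds is known for a change of this kind, so there is no measured basis for expecting a shift in either direction. The step from compound 2 to compound 3 is therefore expected to be a 1.2-fold lower number from compound 2 to compound 3 (0.06 log units; within the scatter), that is, nothing beyond the scatter. Compound 3 is accordingly estimated at 1000000 nM, with a range from 450000 nM to 2200000 nM.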

Compound 3, half-maximal cytotoxic concentration: 545000 nM
The estimate for compound 3 lay 1.8-fold (0.26 log units) above the measured number; low and high end bracket the measured number.
By their numbers in this assay, from the lowest: compounds 3, 1 and 2 (each within the scatter of the next, the first and the last beyond it).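

In this assay, among these compounds, the swap of azido for hydroxy on the saturated ring carbon gives a 2.1-fold lower number from compound 2 to compound 3 (0.33 log units; beyond the scatter) and so lies just beyond the scatter, a modest step but the first single change in this set that can be read on this measure. It points to toxicity in this test responding, if only slightly, to what sits at this ring carbon. Hydrogen in place of fluoro on the aromatic carbon gives a 1.7-fold lower number from compound 1 to compound 3 (0.23 log units; within the scatter) and stays within the scatter, so that change cannot be told apart from no change at all.

On these data alone, whether an amine or a longer chain such as methoxy on the same ring carbon would move the number further, and in which direction, stays open. Why the hydroxy compound gives the lower number also stays open, since nothing measured here bears on the reason.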